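Ring-Closing an Amine on a Low-Inhibition Kinase Scaffold

The source may hold more compounds than are shown below. What is called first, only, known or untested is meant among the compounds shown, and "the series" means these compounds.

In an assay on isolated protein for inhibition of NUAK family SNF1-like kinase 1 (Homo sapiens), read by ADP-Glo, with a stated time of 60 min, tested at 10 uM, in the presence of a further agent that is not named here (on this read-out lower numbers stand for less inhibition and higher numbers for more inhibition at the one concentration tested (going by the name of the read-out)), compound 1 `CCCN(CCC)c1ccc(Nc2ncc(Cl)c(Oc3cccc(NC(=O)CC)c3)n2)cc1` gives 9.3%, the only number shown, and that is a low read-out at the single concentration tested. Compound 2 `CCCN(CCC)c1ccc(Nc2ncc(Cl)c(Oc3cccc(NC(=O)CC)c3)n2)c(OC)c1` is reported in this assay as "not active" (no number reported), without a number. Compound 3 `CCC(=O)Nc1cccc(Oc2nc(Nc3ccc(N4CCC(C)CC4)cc3)ncc2Cl)c1` differs from compound 1 in one place: 4-methylpiperidin-1-yl in place of dipropylamino on an aromatic carbon. For the measured compounds named here, no step between measured compounds exists to guide this, so with compound 1 already near the floor, the step is expected to stay within the scatter, neither up nor down; the expected step is a number 0.7 percentage points higher from compound 1 to compound 3 (within the scatter). Compound 3 is estimated at 10%, with a range from 0% to 30%.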

Compound 3, a percentage reported as inhibition, at one concentration (the size of the read-out at that concentration, not a potency): 13.4%
Compound 3: middle estimate off by 3.4 percentage points, on the low side; the range from low to high includes it.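

In this assay, tying the dipropylamino group into the 4-methylpiperidin-1-yl ring, on an aromatic carbon para to a large group, gives a number 4.1 percentage points higher from compound 1 to compound 3 (within the scatter). At this position, then, an open amine and a ring amine with the same heavy-atom count cannot be told apart on this read-out, and both stay low at the one concentration tested. The data shown hold no evidence that bears on this result.

Still open, on these data alone, is whether a morpholine ring, a piperazine ring or a smaller dimethylamino group here would move the read-out beyond the scatter. Whether any change at this position lifts inhibition well above these low values also remains unanswered.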